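A few compounds are considered here, and "the series" means these few. Any claim that something is new, unique, unknown or untested is made for them only; others in the source may bear on it.

Measured in a functional assay on MDA-MB-231 cells (Homo sapiens) for cytotoxicity, read by MTT assay, with a stated time of 48 h; on this read-out higher numbers stand for weaker inhibition and lower numbers for stronger inhibition:

- compound 1 `COc1ccc(OC)c(C2=NOC(COc3ccc(-c4nnnn4-c4cc(OC)c(OC)c(OC)c4)cc3N)C2)c1`: 3500 nM
- compound 2 `COc1cc(C2=NOC(COc3ccc(-c4nnnn4-c4cc(OC)c(OC)c(OC)c4)cc3N)C2)ccc1O`: 3620 nM
- compound 3 `COc1cc(-n2nnnc2-c2ccc(OCC3CC(c4ccc(OC)c(OC)c4OC)=NO3)c(N)c2)cc(OC)c1OC`: 3540 nM

Compound 3 is not separated from the other two compounds, as all three values lie within the scatter of one another. The next compound to be measured is compound 4 `COc1cc(-n2nnnc2-c2ccc(OCC3CC(c4ccccc4F)=NO3)c(N)c2)cc(OC)c1OC`, which has 2-fluorophenyl in place of 2,3,4-trimethoxyphenyl on a carbon with a double bond to nitrogen.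

Three measured steps change the group at this same place: a 1.0-fold higher number from compound 1 to compound 2 (0.01 log units; within the scatter), a 1.0-fold higher number from compound 1 to compound 3 (0.00 log units; within the scatter) and a 1.0-fold lower number from compound 2 to compound 3 (0.01 log units; within the scatter). All three are within the scatter, so swapping among the three groups tested here leaves the number in this assay essentially unmoved. For the measured compounds named here, these groups all carry oxygen substituents, however, and no measured compound has 2-fluorophenyl at this place. Going by the values given here, the data therefore hold no direct precedent for this replacement, and the range has to stay wide on both sides.

No step beyond the scatter is expected in this assay, and no firm direction can be assigned. The expected step is a 1.2-fold lower number from compound 3 to compound 4 (0.07 log units; within the scatter).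

For compound 4 the estimated value is 3000 nM, with an expected range from 1200 nM to 7500 nM.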

Compound 4, half-maximal inhibitory concentration: 2400 nM
Compound 4: the middle estimate sits 1.3-fold (0.10 log units) above what was measured; low and high end bracket the measured number.
By their numbers in this assay, from the lowest: compounds 4, 1, 3 and 2 (each within the scatter of the next).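

In this assay, for the compounds shown here, compound 4 is the first member with no oxygen substituent on the aryl group at this place, on a carbon with a double bond to nitrogen, and it is not separated from compound 3 (a 1.5-fold lower number from compound 3 to compound 4 (0.17 log units; within the scatter)), from compound 2 (a 1.5-fold lower number from compound 2 to compound 4 (0.18 log units; within the scatter)) or from compound 1 (a 1.5-fold lower number from compound 1 to compound 4 (0.16 log units; within the scatter)). The insensitivity seen among the three oxygen-bearing groups therefore extends to a replacement of 2,3,4-trimethoxyphenyl, with 12 heavy atoms and 3 hydrogen-bond acceptors, by 2-fluorophenyl, with 7 heavy atoms and 0 hydrogen-bond acceptors, so oxygen substituents on this aryl group are not needed to stay within this band among the four compounds shown. No available data explain why the number stays flat at this place.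

The compounds shown leave open whether any group at this place moves the number beyond the scatter, for instance a phenyl ring carrying an amine or a carboxylic acid, or a longer alkyl chain in place of the aryl group. As far as these compounds go, all four also share the same core, so the response to a change anywhere else in the molecule remains unknown.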